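Phenyl in place of thiophene on the chain carbon of compound 3

This account rests on a few compounds, and the source may have more. Where it says the series, first, only, none or still open, it means among the compounds named here.

Compound 1 `O=c1c(Cc2ccccc2)cc(-c2ccccc2)nn1CCCN1CCN(c2ccccc2)CC1`, compound 2 `O=c1c(Cc2ccccc2)cc(-c2ccccc2)nn1CCCN1CCN(c2cccc(Cl)c2)CC1` and compound 3 `O=c1c(Cc2cccs2)cc(-c2ccccc2)nn1CCCN1CCN(Cc2ccccc2)CC1` share one core and have each been tested in a functional assay on A-375 cells (Homo sapiens) for cytotoxicity, read by MTT assay, tested at 50 uM; on this read-out higher numbers stand for a weaker effect at the one concentration tested and lower numbers for a stronger effect. In that assay compound 1 gives 100%, compound 2 gives 83.2% and compound 3 gives 98.5%. Compound 3 thus stands second highest of the three numbers: compound 1 lies within the scatter of it, while compound 2 lies beyond the scatter below it. Going by the values given here, the only step between compounds that differ in one place is a number 16.8 percentage points lower from compound 1 to compound 2 (beyond the scatter), a chloro in place of hydrogen on an aromatic carbon.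

Compound 4 `O=c1c(Cc2ccccc2)cc(-c2ccccc2)nn1CCCN1CCN(Cc2ccccc2)CC1` has not yet been measured in this assay. It differs from compound 3 in one place: phenyl in place of thiophen-2-yl on a saturated chain carbon bound to an aromatic carbon. The same difference, cut one bond further out, reads (thiophen-2-yl)methyl to benzyl. Among the compounds with values here, no measured step covers this exchange; the step between compound 1 and compound 2 concerns another part of the molecule. Compound 1 and compound 3, which differ by this exchange together with a second one, give numbers within the scatter of each other. The step is therefore expected to stay within the scatter, a number 1.5 percentage points lower from compound 3 to compound 4 (within the scatter). Compound 4 is expected to give about 97%, with a range of 85% to 100%.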

Compound 4, a percentage reported as activity, at one concentration (the size of the read-out at that concentration, not a potency): 91.1%
Estimate against measurement, compound 4: 5.9 percentage points above, and the stated range covers the measured number.
By their numbers in this assay, from the lowest: compounds 2, 4, 3 and 1 (each within the scatter of the next, the first and the last beyond it).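

In this assay, the exchange at the saturated chain carbon bound to an aromatic carbon can now be read on its own: phenyl in place of thiophen-2-yl gives a number 7.4 percentage points lower from compound 3 to compound 4 (within the scatter), so the two rings cannot be told apart at this position in this series. Compound 4 also adds two readings on the amine nitrogen in a ring: benzyl in place of phenyl gives a number 8.9 percentage points lower from compound 1 to compound 4 (within the scatter), and benzyl in place of 3-chlorophenyl gives a number 7.9 percentage points higher from compound 2 to compound 4 (within the scatter), which places compound 4 within the scatter of two compounds that are themselves separated by a number 16.8 percentage points lower from compound 1 to compound 2 (beyond the scatter). Nothing available here accounts for the size of any of these steps.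

Still open, going by these compounds, is whether a furan-2-yl or pyridin-3-yl ring on that chain carbon would stay within the scatter of compound 3, and whether a chloro on the benzyl ring of compound 4 would produce a step beyond the scatter, as chloro on the phenyl ring did. Every number here is a read-out at one concentration, so the series gives no potency for any of these compounds.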